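From a Saturated Ring to an Aromatic Ring on the Amide

This account rests on a few compounds, and the source may have more. Where it says the series, first, only, none or still open, it means among the compounds named here.

Of the compounds shown here, three built on one shared core have been tested in a functional assay on LoVo cells (Homo sapiens) for inhibition, read by MTT assay, with a stated time of 72 h; on this read-out higher numbers stand for weaker inhibition and lower numbers for stronger inhibition. Compound 2 `Cc1noc(C)c1-c1cnc(N)c(Oc2ccc(C(=O)NC3CCCC3)cc2)n1` gives 25200 nM. Compound 3 `Cc1noc(C)c1-c1cnc(N)c(Oc2ccc(C(=O)NC3CCCCC3)cc2)n1` gives 21600 nM. Compound 1 `Cc1noc(C)c1-c1cnc(N)c(Oc2ccc(C(=O)NC3CC3)cc2)n1` reaches only a limit of this assay, > 100000 nM, so for it no number is known. Of the two full numbers, compound 2 is the higher one, but its gap to compound 3, a 1.2-fold lower number from compound 2 to compound 3 (0.07 log units; within the scatter), lies within the scatter, so the two cannot be ranked.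

Compound 4 `Cc1noc(C)c1-c1cnc(N)c(Oc2ccc(C(=O)Nc3ccccc3)cc2)n1` has not yet been measured. It differs from compound 2 in one place: phenyl in place of cyclopentyl on an amide-type nitrogen. Within the data shown here, two measured steps concern the same ring on the same nitrogen. The step of an at least 3.9-fold lower number from compound 1 to compound 2 (0.59 log units; beyond the scatter) moved the number down, meaning stronger inhibition, from a cyclopropyl to a cyclopentyl, and the step of an at least 4.6-fold lower number from compound 1 to compound 3 (0.66 log units; beyond the scatter) did much the same for a cyclohexyl. Going on from cyclopentyl to cyclohexyl, a 1.2-fold lower number from compound 2 to compound 3 (0.07 log units; within the scatter), changed nothing beyond the scatter. Swapping cyclopentyl for phenyl, a ring of similar size, is therefore expected to give a step of about a 1.3-fold lower number from compound 2 to compound 4 (0.10 log units; within the scatter) in this assay, no larger than the scatter. Compound 4 is expected to give around 20000 nM, likely between 6000 nM and 60000 nM.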

Compound 4, half-maximal inhibitory concentration: 5740 nM
Compound 4: the middle estimate sits 3.5-fold (0.54 log units) above what was measured; the whole stated range lies above it.
By their numbers in this assay, from the lowest: compound 4; then compounds 3 and 2 (each within the scatter of the next). At a limit, above all of these: compound 1.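

In this assay, the kind of ring on the amide-type nitrogen proves to matter, and not only its size: the two larger saturated rings, cyclopentyl and cyclohexyl, could not be told apart, yet the aromatic phenyl gives a 4.4-fold lower number from compound 2 to compound 4 (0.64 log units; beyond the scatter) and a 3.8-fold lower number from compound 3 to compound 4 (0.58 log units; beyond the scatter). Phenyl adds no hydrogen-bond donors, acceptors or net charge compared with cyclopentyl, and compound 4 is the strongest of the four shown, with the largest step being an at least 17-fold lower number from compound 1 to compound 4 (1.24 log units; beyond the scatter), which fixes only a minimum size. Compound 1 itself stands at a limit: the limit of > 100000 nM in this assay, at which 1 of the 4 values shown sits.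

With a single aromatic ring on this nitrogen, the compounds shown do not tell why phenyl differs from the saturated rings, nor whether any aromatic ring would do the same. On these data alone, a pyridyl ring, a benzyl group, or a phenyl ring carrying a chlorine or a methoxy group would each show how far this step holds, and whether it carries over to cells other than those used here remains open as well.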